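From a Hexylamide to a Piperidinyl Amide

This account rests on a few compounds, and the source may have more. Where it says the series, first, only, none or still open, it means among the compounds named here.

Measured compounds:
compound 1, `CCNC(=O)CC1CCc2cc(OC)c(OC)cc21`: 26.6%
compound 2, `CCCCCCNC(=O)CC1CCc2cc(OC)c(OC)cc21`: 42.1%

In a functional assay on the whole organism (strain Wistar) for inhibition, with Rattus norvegicus as the target, read by paw edema, with stated times of 60 min and 4 h, at a dose of 100 mg/kg by the oral route (on this read-out lower numbers stand for less inhibition and higher numbers for more inhibition at the one dose given (going by the name of the read-out)), compound 2 gives 42.1%, the higher of the two numbers, while compound 1 gives 26.6%. For the measured compounds named here, the only step available is a number 15.5 percentage points higher from compound 1 to compound 2 (beyond the scatter), so lengthening the chain on the amide nitrogen raised the read-out modestly. Compound 3, `COc1cc2c(cc1OC)C(CC(=O)N1CCCCC1)CC2`, differs from compound 2 in another way: piperidin-1-yl in place of hexylamino on a carbonyl carbon. Going by the values given here, this exchange of a hexylamino group for a ring of similar size has no measured counterpart here; the step from compound 1 to compound 2 bears on it only loosely, as both changes alter what sits on the amide. A step of small size in either direction, or none beyond the scatter, is expected, a number 6.1 percentage points lower from compound 2 to compound 3 (within the scatter). Compound 3 is therefore estimated at 36%, with a range from 22% to 50%.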

Compound 3, a percentage reported as inhibition, in the whole organism at one dose (the size of the read-out at that dose, not a potency): 32%
Compound 3: middle estimate off by 4 percentage points, on the high side; low and high end bracket the measured number.
By their numbers in this assay, from the lowest: compounds 1 and 3 (each within the scatter of the next); then compound 2.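

In this assay, piperidin-1-yl in place of hexylamino on a carbonyl carbon gives a number 10.1 percentage points lower from compound 2 to compound 3 (beyond the scatter), so the gain seen with the longer chain is not kept when a ring of nearly the same heavy-atom count takes its place. Set against the short chain, piperidin-1-yl in place of ethylamino gives a number 5.4 percentage points higher from compound 1 to compound 3 (within the scatter), which leaves the ring and ethylamino level on this read-out. No measurement at hand bears on the cause of these steps.

As far as these compounds go, it remains open whether the loss follows from the missing amide hydrogen or from the closed ring, a question that a tertiary amide with two open chains, such as diethylamino, would bear on. Also open, from the compounds shown here alone, is how a longer chain such as octylamino, or rings such as pyrrolidin-1-yl and morpholin-4-yl, would compare on the same carbonyl carbon.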